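The compounds below may be only part of what the source reports. "The series", "measured", "known", "first", "only" and "open" are said of these compounds alone.

Compound 1, `Nc1nc(NCc2cccs2)nc2sc(-c3ccco3)nc12`, is the reference point of this set. In an assay on CHO cells for displacement of a labelled ligand from adenosine receptor A3 (Homo sapiens), read by scintillation counting, with a stated time of 120 min (a higher number here means a weaker inhibitor, a lower number a stronger inhibitor), compound 1 gives 6.43 nM, the lowest of the three numbers. Its nearest neighbour is compound 3, `Cc1ccc(-c2nc3c(N)nc(NCc4cccs4)nc3s2)o1`, which gives 15.3 nM; the step of a 2.4-fold higher number from compound 1 to compound 3 (0.38 log units; beyond the scatter) is modest but beyond the scatter. Within the data shown here, the third measured compound, compound 2, `COc1ccccc1CNc1nc(N)c2nc(-c3cccs3)sc2n1`, gives 275 nM, the highest of the three by a wide margin; it differs from compound 1 in more than one place, so no single step is drawn between them.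

The new compound is compound 4, `Nc1nc(NCc2ccncc2)nc2sc(-c3ccco3)nc12`. It differs from compound 1 as follows: pyridin-4-yl in place of thiophen-2-yl on a saturated chain carbon bound to a nitrogen on an aromatic ring. Among the measured compounds shown here, no measured step changes this part of the molecule on its own. For the measured compounds named here, the only step available, that from compound 1 to compound 3, concerns a methyl on the other aromatic ring and was modest. Compound 2, which carries a different group at the same saturated chain carbon among its changes, shows a much weaker number than compound 1, so swapping the group there has room to cost potency. Compound 4 is therefore expected to show a moderate weakening, a 3.1-fold higher number from compound 1 to compound 4 (0.49 log units; beyond the scatter), and its estimated value is 20 nM, with a range from 6 nM to 80 nM.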

Compound 4, inhibition constant: 827 nM
The estimate for compound 4 lay 41-fold (1.62 log units) below the measured number; measured number outside the range, above it.
By their numbers in this assay, from the lowest: compound 1; then compound 3; then compound 2; then compound 4.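

In this assay, replacing (thiophen-2-yl)methyl with (pyridin-4-yl)methyl gives a 130-fold higher number from compound 1 to compound 4 (2.11 log units; beyond the scatter), so this position on a saturated chain carbon bound to a nitrogen on an aromatic ring is sensitive to the ring it carries, even though the two groups have the same counts of hydrogen-bond donors and acceptors and neither has a net charge. This is the only single-place change at this position among the compounds shown, and its step is far larger than that of methyl in place of hydrogen on an aromatic carbon, a 2.4-fold higher number from compound 1 to compound 3 (0.38 log units; beyond the scatter). Nothing in the material at hand explains the size of the step to pyridin-4-yl.

Going by these compounds, it remains open whether the loss belongs to pyridin-4-yl specifically or would extend to other six-membered aromatic rings at the same place, such as an unsubstituted phenyl or a pyridin-3-yl group. On these data alone, it is also open whether the same ring change would cost as much in the presence of the methyl carried by compound 3.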